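The source may report more compounds than this note shows. Statements on the series, on what has been measured and on what is new or still open speak of the compounds shown alone.

Compound 1 `Cc1cc(Nc2cc(-c3ccccc3)[nH]n2)n2ncnc2n1` in a functional assay on PC-9 cells (Homo sapiens) for inhibition, read by MTT assay, with a stated time of 72 h (a higher number here means a weaker inhibitor, a lower number a stronger inhibitor), gives > 50000 nM, a limit of the assay.
Compound 2 `Cc1cc(Nc2cc(-c3ccccc3)[nH]n2)n2nc(SCc3csc4ccccc34)nc2n1` in this assay gives 4420 nM.
Compound 3 `CCCCCc1c(C)nc2nc(SCc3ccc(Cl)cc3)nn2c1Nc1cc(-c2ccccc2)[nH]n1` in this assay gives > 50000 nM, a limit of the assay.

Among the compounds with values here, compound 2 stands alone as the only genuine number among the three results; the other two compounds sit at the limit of > 50000 nM in this assay, at which 2 of the 3 values shown sit. Compound 4 `Cc1cc(Nc2cc(-c3ccccc3)[nH]n2)n2nc(SCc3ccc(F)cc3)nc2n1` differs from compound 2 by 4-fluorophenyl in place of 1-benzothiophen-3-yl on a saturated chain carbon bound to a sulfur. Within the data shown here, the single step measured between compounds that differ in one place is an at least 11-fold lower number from compound 1 to compound 2 (1.05 log units; beyond the scatter), which shows that the sulfanyl substituent on the shared core carries the whole gain seen so far. Compound 4 keeps that sulfanyl substituent and keeps a benzylic carbon on it, but swaps the aryl for a smaller one. Among the measured compounds shown here, no measured step exchanges one aryl for another on the sulfanyl group, so the size of the effect has no direct precedent. Compound 3, which also carries a halogenated benzyl sulfanyl on the core but differs from compound 2 in a second place as well, shows only a limit. Weighing the large gain from adding the sulfanyl group against the loss of the larger aryl, compound 4 is expected to remain measurable but to fall short of compound 2, with an expected step of a 2.7-fold higher number from compound 2 to compound 4 (0.43 log units; beyond the scatter). Compound 4 is estimated at 12000 nM, within 3000 nM to 50000 nM.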

Compound 4, half-maximal inhibitory concentration: 8110 nM
Estimate against measurement, compound 4: 1.5-fold (0.17 log units) above; the range from low to high includes it.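

On a saturated chain carbon bound to a sulfur, 1-benzothiophen-3-yl is not the only aryl that gives a measurable value: in this assay, 4-fluorophenyl in its place gives a 1.8-fold higher number from compound 2 to compound 4 (0.26 log units; within the scatter), so the two compounds cannot be told apart. The gain on the aromatic carbon of the shared core is therefore seen with a second sulfanyl group, and (4-fluorobenzyl)sulfanyl in place of hydrogen gives an at least 6.1-fold lower number from compound 1 to compound 4 (0.78 log units; beyond the scatter). Compound 1 stands at a limit of the assay, so that step gives a bound and not a measured size: the limit of > 50000 nM in this assay, at which 2 of the 4 values shown sit.

The compounds shown leave open whether an aryl is needed on the sulfanyl group at all, which a plain methyl or a longer chain in its place would test, and whether an amine or a carboxylic acid on the benzyl ring would be tolerated. Compound 3 also gives a limit of the assay, but it differs from compound 2 and compound 4 in more than one place, so it cannot show which of its differences matters.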